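Adding a chloropentynyl chain to a weakly active triazole

This account rests on a few compounds, and the source may have more. Where it says the series, first, only, none or still open, it means among the compounds named here.

Measured compounds:
compound 1, `O=c1nc2oc(CCCCl)c(C#CCCCCl)c2cn1Cc1cn(Cc2ccccc2)nn1`, 33900 nM in a functional assay on SW-620 cells (Homo sapiens) for antiproliferative activity, read by MTT assay, with a stated time of 72 h; on this read-out lower numbers stand for stronger inhibition and higher numbers for weaker inhibition
compound 2, `O=c1nc2oc(CCCCl)cc2cn1Cc1cn(-c2ccc(Cl)cc2)nn1`, > 100000 nM

Compound 1 carries both a 3-chloropropyl group and a 5-chloropent-1-yn-1-yl group on the shared core, with a benzyl group on the triazole, and in this assay compound 1 gives 33900 nM. Compound 2 keeps the 3-chloropropyl group but lacks the chloropentynyl chain and has a 4-chlorophenyl group on the triazole; in this assay compound 2 gives only > 100000 nM, which is a limit of the assay and not a number, and the limit of > 100000 nM in this assay, at which 1 of the 2 values shown sits, shows where that limit lies. Compound 2 therefore stands at the weak end of the numbers shown.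

Compound 3, `O=c1nc2oc(CCCCl)c(C#CCCCCl)c2cn1Cc1cn(-c2ccc(Cl)cc2)nn1`, arises from compound 2 by the change (5-chloropent-1-yn-1-yl in place of hydrogen on an aromatic carbon). Among the compounds with values here, no measured pair shows this change on its own. In this assay compound 3 is expected to come out around 40000 nM, within 12000 nM to 130000 nM, because compound 1, which bears the same chloropentynyl group, gives 33900 nM. That estimate means a step of an at least 2.5-fold lower number from compound 2 to compound 3 (0.39 log units; beyond the scatter), though a result that is again only a limit remains quite possible.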

Compound 3, half-maximal inhibitory concentration: > 100000 nM
Compound 3: a limit, no number; the forecaster's own chance of this, stated with the estimate: 40%; at least 2.5-fold (0.39 log units) between middle value and limit.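

In this assay compound 3 gives > 100000 nM, which is a limit of the assay and not a number. The step that adds the 5-chloropent-1-yn-1-yl group cannot be read, because compound 2 and compound 3 both stop at the same limit: the limit of > 100000 nM in this assay, at which 2 of the 3 values shown sit. The step that can be read concerns the triazole instead: with the chloropentynyl chain present in both compounds, 4-chlorophenyl in place of benzyl on an aromatic nitrogen gives an at least 2.9-fold higher number from compound 1 to compound 3 (0.46 log units; beyond the scatter), so among these three compounds the chain gives a measurable number only alongside benzyl.

As far as these compounds go, the effect of the chain itself stays open, since reading it would take a pair of compounds with benzyl on the triazole that differ only in having the 5-chloropent-1-yn-1-yl group or hydrogen at this aromatic carbon. Also open, from the compounds shown here alone, is how a shorter chain, an amine or a carboxylic acid at the same carbon would behave.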